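Removing the pyridinyl group: a large gain in inhibition

A few compounds are considered here, and "the series" means these few. Any claim that something is new, unique, unknown or untested is made for them only; others in the source may bear on it.

Measured compounds in an assay on isolated protein for inhibition of sterol O-acyltransferase 1 (Mus musculus), tested at 0.1 uM; on this read-out lower numbers stand for less inhibition and higher numbers for more inhibition at the one concentration tested (going by the name of the read-out):
compound 1, `CCCCCCCCCCCCn1nnc(C(C(=O)Nc2c(OC)cc(OC)cc2OC)c2ccccn2)n1`, gives 23%
compound 2, `CCCCCCCCCCCCn1nnc(C(C(=O)Nc2c(C(C)C)cccc2C(C)C)c2ccccn2)n1`, gives 24%
compound 3, `CCCCCCCCCCCCn1nnc(CC(=O)Nc2c(C(C)C)cccc2C(C)C)n1`, gives 91%

Compound 1 and compound 2 differ only in the group on the amide nitrogen; the difference between the two cores is 2,4,6-trimethoxyphenyl in place of 2,6-diisopropylphenyl on an amide-type nitrogen. In this assay that swap made a step of a number 1 percentage points higher from compound 1 to compound 2 (within the scatter), so the two values cannot be told apart. Compound 3 is made from compound 2 by a single change, (hydrogen in place of pyridin-2-yl on a saturated chain carbon bound to an aromatic carbon and a carbonyl carbon), and that change produced a step of a number 67 percentage points higher from compound 2 to compound 3 (beyond the scatter).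

Compound 4, `CCCCCCCCCCCCn1nnc(CC(=O)Nc2c(OC)cc(OC)cc2OC)n1`, has not been measured yet. It arises from compound 1 by hydrogen in place of pyridin-2-yl on a saturated chain carbon bound to an aromatic carbon and a carbonyl carbon, which is the same change, at a place described in identical words. For compound 4 a step of a number 62 percentage points higher from compound 1 to compound 4 (beyond the scatter) is therefore expected, because the earlier step of a number 67 percentage points higher from compound 2 to compound 3 (beyond the scatter) was large while the core swap barely mattered. Compound 4 is estimated to give 85% in this assay, expected to lie between 60% and 97%.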

Compound 4, a percentage reported as inhibition, at one concentration (the size of the read-out at that concentration, not a potency): 66%
Compound 4: middle estimate off by 19 percentage points, on the high side; low and high end bracket the measured number.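

In this assay, hydrogen in place of pyridin-2-yl on the second core gives a number 43 percentage points higher from compound 1 to compound 4 (beyond the scatter), so the change raises inhibition on both cores shown. The size of the gain does not carry over unchanged, as the two steps differ by more than repeated measurements would explain: the same change on two cores in this assay, a number 67 percentage points higher (beyond the scatter) from compound 2 to compound 3 and a number 43 percentage points higher (beyond the scatter) from compound 1 to compound 4, 24 percentage points apart, beyond the scatter of two such steps. These two pairs show that the direction held while the size changed with the group on the amide nitrogen, but they cannot show how large the gain would be on any other core, nor why the two steps differ.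

As far as these compounds go, it remains open whether a small group such as methyl or a fluorine atom on the saturated chain carbon would keep the inhibition seen with hydrogen or lose it as pyridin-2-yl does. From the compounds shown here alone, it is equally open how the step would behave with a plain phenyl group on the amide nitrogen, or with a shorter chain in place of the long one on the shared core.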